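The source may report more compounds than this note shows. Statements on the series, on what has been measured and on what is new or still open speak of the compounds shown alone.

Of the compounds shown here, three sharing one core have been measured in a physicochemical assay for solubility, using the shake flask method, in simulated intestinal fluid, measured as kinetic solubility, with a stated time of 2 h, at 25 degrees C, at pH 6.5; on this read-out lower numbers stand for lower solubility and higher numbers for higher solubility. Compound 1 `Cc1noc(-c2nc(C)c3c(c2N)C(=O)N(CC2CCOCC2)C3=O)n1` gives 5700 nM, and compound 3 `Cc1noc(-c2nc(C)c3c(c2N)C(=O)N(C(C)c2ccccc2)C3=O)n1` gives 10900 nM. Compound 2 `Cc1noc(-c2nc(C)c3c(c2N)C(=O)N(Cc2ccc(Br)cc2)C3=O)n1` gives only a limit in this assay, < 5000 nM. Its standing is thus set by the limit of < 5000 nM in this assay, at which 1 of the 3 values shown sits, and it cannot be ranked against the other two beyond that. The measured steps, an at least 1.1-fold lower number from compound 1 to compound 2 (0.05 log units; that floor lies within the scatter), a 1.9-fold higher number from compound 1 to compound 3 (0.28 log units; within the scatter) and an at least 2.1-fold higher number from compound 2 to compound 3 (0.33 log units; beyond the scatter), each exchange the whole group on the ring nitrogen. Compound 4 `Cc1noc(-c2nc(C)c3c(c2N)C(=O)N(Cc2ccc(S(C)(=O)=O)cc2)C3=O)n1` differs from compound 2 by methylsulfonyl in place of bromo on an aromatic carbon. Going by the values given here, no measured step changes a substituent on the aromatic ring, so these steps give only the range in which the series sits. Compound 4 is expected near 8000 nM, between 3000 nM and 25000 nM, an estimated step of an at least 1.6-fold higher number from compound 2 to compound 4 (0.20 log units; that floor lies within the scatter).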

Compound 4, solubility: < 5000 nM
Compound 4 gave a limit, no number (the forecaster's own chance of this, stated with the estimate: 25%); middle value at least 1.6-fold (0.20 log units) from the limit.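

In this assay compound 4 gives < 5000 nM, a limit and not a number, so methylsulfonyl in place of bromo on this aromatic carbon still yields no measured number. Going by these compounds alone, the step between these two compounds cannot be read, because both sit at the same limit: the limit of < 5000 nM in this assay, at which 2 of the 4 values shown sit. The one readable step, with 4-(methylsulfonyl)phenyl in place of oxan-4-yl, is an at least 1.1-fold lower number from compound 1 to compound 4 (0.05 log units; that floor lies within the scatter).

Going by these compounds, whether an amine or a carboxylic acid on this aromatic carbon would give a number in this assay stays open. On these data alone, the actual values behind the limits of compound 2 and compound 4 also remain unknown.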